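The source may hold more compounds than are shown below. What is called first, only, known or untested is meant among the compounds shown, and "the series" means these compounds.

Measured so far in a functional assay (thoracic aorta) for inhibition, with Rattus norvegicus as the target; on this read-out higher numbers stand for weaker inhibition and lower numbers for stronger inhibition:
- compound 1 `CC(C)c1ccc2c(CCCCNS(=O)(=O)c3ccccc3)cc(C(=O)O)c-2cc1`: 70 nM
- compound 2 `COc1ccc(S(=O)(=O)NCCCCc2cc(C(=O)O)c3ccc(C(C)C)ccc2-3)cc1`: 160 nM

In this assay, among the compounds with values here, compound 2 at 160 nM has the higher of the two numbers, with compound 1 as its only neighbour. Compound 3 `CC(C)c1ccc2c(CCCCNS(=O)(=O)c3ccc(F)cc3)cc(C(=O)O)c-2cc1` is the next to be read. It differs from compound 2 by fluoro in place of methoxy on an aromatic carbon, para to a large group, which amounts to 4-methoxyphenyl to 4-fluorophenyl.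

Within the data shown here, one measured step bears on this change. Methoxy in place of hydrogen on an aromatic carbon gave a 2.3-fold higher number from compound 1 to compound 2 (0.36 log units; beyond the scatter), a modest step just beyond the scatter. Compound 3 also loses the methoxy, so a modest step back toward compound 1 at 70 nM is expected, meaning a lower number and stronger inhibition. Among the measured compounds shown here, no fluoro compound has been measured, so the size of the step is uncertain and the range stays wide.

The expected step is a 1.8-fold lower number from compound 2 to compound 3 (0.25 log units; within the scatter). For compound 3 the estimated value is 90 nM, with an expected range of 40 nM to 200 nM.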

Compound 3, half-maximal inhibitory concentration: 11 nM
Estimate against measurement, compound 3: 8.2-fold (0.91 log units) above; measured number outside the range, below it.
By their numbers in this assay, from the lowest: compound 3; then compound 1; then compound 2.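

In this assay, within the data shown here, the aromatic carbon para to a large group proves far more sensitive than the single methoxy step suggested, with fluoro in place of methoxy giving a 15-fold lower number from compound 2 to compound 3 (1.16 log units; beyond the scatter) in a large step. Fluoro in place of hydrogen gives a 6.4-fold lower number from compound 1 to compound 3 (0.80 log units; beyond the scatter) as a modest step, so removing the methoxy is not simply a return to the level of the unsubstituted phenyl: against hydrogen at this carbon, methoxy raises the number and fluoro lowers it, and the two groups pull in opposite directions, with compound 3 giving the strongest inhibition of the three. Nothing available accounts for this gap between the fluoro and methoxy groups.

As far as these compounds go, with only hydrogen, methoxy and fluoro compared at this carbon, it remains open whether the lower number is particular to fluoro or extends to chloro, trifluoromethyl or a nitrile. Among these compounds, it also remains open whether the gain from the 4-fluorophenyl group would hold with a shorter or longer chain in place of the one shared by these compounds, or with an amide in place of the carboxylic acid on the shared core.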